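A Chain-Extended Methyl Ester Follows the Free Acid

A few compounds are considered here, and "the series" means these few. Any claim that something is new, unique, unknown or untested is made for them only; others in the source may bear on it.

Compound 1, `O=C(O)CCCC[C@H](NC(=O)OCc1ccccc1)C(=O)NC1CCCC1`: 20%
Compound 2, `COC(=O)CCCC[C@H](NC(=O)OC(C)(C)C)C(=O)NC1CCCC1`: 40%

In an assay on isolated protein for inhibition of protein deacetylase HDAC6 (Homo sapiens), read by fluorescence, tested at 1 uM (on this read-out higher numbers stand for more inhibition at the one concentration tested (going by the name of the read-out) and lower numbers for less inhibition), compound 1 gives 20%, the lower of the two numbers, while compound 2 gives 40%, a gap beyond the usual scatter. Compound 3, `COC(=O)CCCCC[C@H](NC(=O)OCc1ccccc1)C(=O)NC1CCCC1`, has not been measured. It differs from compound 1 in one place: (methoxycarbonyl)methyl in place of carboxy on a saturated chain carbon, five bonds along the chain from an amide-type nitrogen and a carbonyl carbon. For the measured compounds named here, no measured step of this kind exists, so the direction rests on compound 2, whose number of 40% stands higher. The step from compound 1 to compound 3 is therefore expected to be a moderate rise, a number 15 percentage points higher from compound 1 to compound 3 (beyond the scatter). Compound 3 is estimated at 35%, between 15% and 60%.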

Compound 3, a percentage reported as inhibition, at one concentration (the size of the read-out at that concentration, not a potency): 65%
Compound 3: the middle estimate sits 30 percentage points below what was measured; measured number outside the range, above it.
By their numbers in this assay, from the lowest: compound 1; then compound 2; then compound 3.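

At this place on the saturated chain, five bonds along the chain from an amide-type nitrogen and a carbonyl carbon, (methoxycarbonyl)methyl in place of carboxy gives a number 45 percentage points higher from compound 1 to compound 3 (beyond the scatter) in this assay as a large step. Inhibition in this series therefore does not depend on keeping the free carboxy group at this place. Nothing available explains the rise.

The single change both adds a chain carbon and replaces the acid with a methyl ester, and the compounds shown do not separate these two parts. Going by these compounds, how an amine or a hydroxamic acid would fare at the chain end remains open.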